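Extending the alkyne on a pyrimidine nucleoside

This account rests on a few compounds, and the source may have more. Where it says the series, first, only, none or still open, it means among the compounds named here.

Measured compounds:
compound 1, `CC1(C)[C@@H](CO)CC[C@@]1(C)Cn1cnc2c(Cl)ncnc21`, 42800 nM
compound 2, `C#Cc1cn([C@@H]2O[C@H](CO)[C@@H](O)[C@@H]2O)c(=O)[nH]c1=O`, 168000 nM
compound 3, `O=c1[nH]c(=O)n(COCCO)cc1[N+](=O)[O-]`, > 200000 nM

Of the compounds shown here, three have been measured in an ADME assay on L1210/0 cells (Mus musculus) for cytotoxicity, with a stated time of 48 h; a lower number here means a stronger inhibitor, a higher number a weaker inhibitor. Compound 1 gives 42800 nM. Compound 2 gives 168000 nM, which is the highest of the two numbers reported; its nearest neighbour is compound 1, whose number is lower by a margin beyond the scatter. For compound 3 the assay reports only a limit, > 200000 nM, and not a number, so it cannot be placed against the others (the limit of > 200000 nM in this assay, at which 1 of the 3 values shown sits).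

The step followed here leads from compound 2 to the unmeasured compound 4, `CC(C)(C)C#Cc1cn([C@@H]2O[C@H](CO)[C@@H](O)[C@@H]2O)c(=O)[nH]c1=O`. The change is tert-butyl in place of hydrogen on a triple-bonded carbon. Going by the values given here, no pair of measured compounds differs in a single place, so there is no measured step of this kind to lean on. Compound 2 already sits at a weak level in this assay, and the analogues shown give no sign that adding a tert-butyl on the triple-bonded carbon would move the number far. The expectation is for a step from compound 2 to compound 4 of a 1.8-fold higher number from compound 2 to compound 4 (0.25 log units; within the scatter), a small shift or none beyond the scatter, with a real chance that only a limit is returned. Compound 4 is therefore estimated at 300000 nM in this assay, within 80000 nM to 1000000 nM.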

Compound 4, half-maximal inhibitory concentration: > 200000 nM
Compound 4 ended at the assay's limit; the forecaster's own chance of this, stated with the estimate: 50%; the middle value does not contradict the limit.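

In this assay compound 4 returns > 200000 nM, which is a limit of the assay and not a number. Read as a step, this gives an at least 1.1-fold higher number from compound 2 to compound 4 (0.07 log units; that floor lies within the scatter), the first change in a single place among these compounds, and it fixes only a floor, so it shows that tert-butyl in place of hydrogen on a triple-bonded carbon brings no lower number but not that the number truly rises beyond the scatter. The triple-bonded carbon thus proves open to a group of this size without any gain in this read-out, and compound 4 joins the values that stop at the top of the assay's range: the limit of > 200000 nM in this assay, at which 2 of the 4 values shown sit.

The compounds shown leave open how far past the limit compound 4 really lies, and so whether this change weakens the compound at all or leaves it where compound 2 stands. They also leave open whether a different group on the triple-bonded carbon, such as a phenyl ring, a longer straight chain or a chain ending in an amine, would give a number lower than that of compound 2.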